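A few compounds are considered here, and "the series" means these few. Any claim that something is new, unique, unknown or untested is made for them only; others in the source may bear on it.

Measured so far in a physicochemical assay for solubility, with a stated time of 18 h, at pH 7.4; on this read-out lower numbers stand for lower solubility and higher numbers for higher solubility:
- Compound 1 `FC(F)(F)c1ccc(-c2ccc3c(NCCCNCc4ccco4)ccnc3c2)cc1`: 32000 nM
- Compound 2 `CN(C)c1cccc(Oc2ccc3c(NCCCNCc4ccco4)ccnc3c2)c1`: 14500 nM

Compound 2 holds the lower of these two numbers. Within the data shown here, the one measured step is a 2.2-fold lower number from compound 1 to compound 2 (0.34 log units; beyond the scatter), and it is modest. In that step, 3-(dimethylamino)phenoxy took the place of 4-(trifluoromethyl)phenyl on an aromatic carbon.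

Compound 3 `Fc1ccc(Cc2ccc3c(NCCCNCc4ccco4)ccnc3c2)cc1` is still unmeasured and changes the same carbon of the shared core: 4-fluorobenzyl in place of 3-(dimethylamino)phenoxy on an aromatic carbon. Here 4-fluorobenzyl comes in place of 3-(dimethylamino)phenoxy, so the group that entered in the measured step leaves again.

Among the measured compounds shown here, no measured compound carries 4-fluorobenzyl, so the single step of a 2.2-fold lower number from compound 1 to compound 2 (0.34 log units; beyond the scatter) is the only guide, and it gives a size rather than a firm direction. A small move towards the higher number of compound 1, at 32000 nM, is therefore expected, and it may well stay inside the scatter. The expected step is a 1.4-fold higher number from compound 2 to compound 3 (0.14 log units; within the scatter). For compound 3 the estimated value in this assay is 20000 nM, with an expected range from 8000 nM to 50000 nM.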

Compound 3, solubility: 4200 nM
The estimate for compound 3 lay 4.8-fold (0.68 log units) above the measured number, and the stated range ends above it.
By their numbers in this assay, from the lowest: compound 3; then compound 2; then compound 1.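

Compound 3 shows that this aromatic carbon of the shared core can take the read-out of this assay further down than the first pair suggested, and that removing 3-(dimethylamino)phenoxy does not by itself lead back towards compound 1 (a 3.5-fold lower number from compound 2 to compound 3 (0.54 log units; beyond the scatter)). Both steps into 4-fluorobenzyl point the same way and lie beyond the scatter, whichever group leaves, and the one from the 4-(trifluoromethyl)phenyl compound spans the whole measured spread (a 7.6-fold lower number from compound 1 to compound 3 (0.88 log units; beyond the scatter)), so all three groups on this carbon stand apart in their numbers. The leaving and entering groups differ in their count of hydrogen-bond acceptors, 2 against 0, yet nothing measured here connects that count, or any other feature of 4-fluorobenzyl, to the lower number.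

The compounds shown leave open which part of 4-fluorobenzyl goes with the drop, and a plain benzyl or a 4-fluorophenyl on the same carbon would separate the fluorine from the carbon link. They also leave open whether a morpholine or a carboxylic acid at this carbon would raise the number above that of compound 1, and how the furan-bearing chain, unchanged throughout, contributes.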